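A Methyl Branch Added to the Chain of Compound 3

The source may report more compounds than this note shows. Statements on the series, on what has been measured and on what is new or still open speak of the compounds shown alone.

Compound 1 `COc1cc(OC)cc(C(=O)NC2CCN(C(C)c3ccc4ccccc4c3)CC2)c1` gives 25 nM in an assay on isolated protein for binding affinity to melanin-concentrating hormone receptor 1 (Homo sapiens); a lower number here means a stronger inhibitor, a higher number a weaker inhibitor. Compound 2 `COc1cc(OC)cc(C(=O)N[C@@H]2CCN(C(C)c3ccc4ccccc4c3)C2)c1` gives 12 nM in this assay. Compound 3 `COc1cc(OC)cc(C(=O)N[C@@H]2CCN(C/C=C/c3ccccc3)C2)c1` gives 17 nM in this assay.

Among these three numbers, compound 3 sits with compound 2 on one side and compound 1 on the other, and both gaps stay within the usual scatter of repeated measurements, so the three compounds cannot be told apart on these numbers alone.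

Compound 4 `COc1cc(OC)cc(C(=O)N[C@@H]2CCN(C(C)/C=C/c3ccccc3)C2)c1` has not yet been measured in this assay. It differs from compound 3 in one place: methyl in place of hydrogen on a saturated chain carbon bound to an amine nitrogen in a ring and a double-bonded chain carbon. The same kind of branch, a methyl on the carbon bound to the ring amine nitrogen, is already present in compound 1 and compound 2, whereas compound 3 has a hydrogen there, and the values of compound 2 and compound 3 lie within the scatter of each other. No single-point comparison between measured compounds covers exactly this change, so the expectation rests on that loose parallel. The step from compound 3 to compound 4 is expected to be a 1.1-fold lower number from compound 3 to compound 4 (0.05 log units; within the scatter), that is, no change beyond the scatter in either direction. Compound 4 is therefore estimated at 15 nM, with a range from 6 nM to 40 nM.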

Compound 4, inhibition constant: 23 nM
Compound 4: the middle estimate sits 1.5-fold (0.19 log units) below what was measured, within the range that was stated.
By their numbers in this assay, from the lowest: compounds 2, 3, 4 and 1 (each within the scatter of the next, the first and the last beyond it).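

In this assay, within the data shown here, methyl in place of hydrogen on a saturated chain carbon bound to an amine nitrogen in a ring and a double-bonded chain carbon gives a 1.4-fold higher number from compound 3 to compound 4 (0.13 log units; within the scatter), the first direct reading of this branch, and the added carbon produces no change that can be told from the scatter. Among these compounds, compound 4 also provides the first single-place comparison of the two aromatic ends: with the methyl branch present in both compounds, 2-phenylethenyl in place of naphthalen-2-yl gives a 1.9-fold higher number from compound 2 to compound 4 (0.28 log units; within the scatter), so this exchange also stays inside the scatter of this assay. No measurement here explains why either change leaves the number within the scatter.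

On these data alone, it remains open whether this chain carbon would give a similar reading with a larger group, such as ethyl or cyclopropyl, or with a hydroxymethyl group that carries an oxygen atom. As far as these compounds go, it is equally open whether the 2-phenylethenyl end would keep its value with a chlorine atom or a methoxy group on its phenyl ring, or with a longer chain between that ring and the amine nitrogen.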